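Predicting a Piperazine Swap on a Second Core

A few compounds are considered here, and "the series" means these few. Any claim that something is new, unique, unknown or untested is made for them only; others in the source may bear on it.

Of the compounds shown here, three have been tested in a functional assay on A549 cells (Homo sapiens) for antiproliferative activity, read by MTT assay, with a stated time of 72 h (on this read-out lower numbers stand for stronger inhibition and higher numbers for weaker inhibition), and a fourth awaits its number. Compound 1 `COc1cc2ncnc(N3CCc4ccccc43)c2cc1NC(=O)/C=C/CN1CCCCC1` gives 2540 nM in this assay. Compound 2 `COc1cc2ncnc(N3CCc4ccccc43)c2cc1NC(=O)/C=C/CN1CCN(C)CC1` differs from compound 1 in one place, the change being (4-methylpiperazin-1-yl in place of piperidin-1-yl on a saturated chain carbon bound to a double-bonded chain carbon); in this assay compound 2 gives 5360 nM, and the step of a 2.1-fold higher number from compound 1 to compound 2 (0.32 log units; beyond the scatter) is a modest weakening of the antiproliferative effect.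

Compound 3 `COc1cc2ncnc(N3CCCc4ccccc43)c2cc1NC(=O)/C=C/CN1CCCCC1` carries a different core, the difference from compound 1 being (1,2,3,4-tetrahydroquinolin-1-yl in place of 2,3-dihydro-1H-indol-1-yl on an aromatic carbon). In this assay compound 3 gives 2880 nM, and the step of a 1.1-fold higher number from compound 1 to compound 3 (0.05 log units; within the scatter) shows that the two cores behave alike here.

Compound 4 `COc1cc2ncnc(N3CCCc4ccccc43)c2cc1NC(=O)/C=C/CN1CCN(C)CC1` is not yet measured. It stands to compound 3 as compound 2 stands to compound 1: the change is 4-methylpiperazin-1-yl in place of piperidin-1-yl on a saturated chain carbon bound to a double-bonded chain carbon, at the same place as before, so it is the same change made on the second core. Since the two cores gave near-identical numbers with the piperidin-1-yl group, the expectation is that the swap will cost about as much on compound 3 as it did on compound 1, and the step from compound 3 to compound 4 is estimated as a 2.1-fold higher number from compound 3 to compound 4 (0.32 log units; beyond the scatter), resting on the step of a 2.1-fold higher number from compound 1 to compound 2 (0.32 log units; beyond the scatter). On that basis compound 4 is expected to give about 6000 nM, with a plausible range from 3000 nM to 12000 nM.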

Compound 4, half-maximal inhibitory concentration: 7830 nM
Compound 4: the middle estimate sits 1.3-fold (0.12 log units) below what was measured; the measured number falls inside the stated range.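

In this assay, putting 4-methylpiperazin-1-yl in place of piperidin-1-yl on the second core gives a 2.7-fold higher number from compound 3 to compound 4 (0.43 log units; beyond the scatter), and this step agrees with the one seen on the first core: the same change on two cores in this assay, a 2.1-fold higher number (0.32 log units; beyond the scatter) from compound 1 to compound 2 and a 2.7-fold higher number (0.43 log units; beyond the scatter) from compound 3 to compound 4, 1.3-fold (0.11 log units) apart, within the scatter of two such steps

The reverse view tells the same story, since exchanging the core while 4-methylpiperazin-1-yl stays in place gives a 1.5-fold higher number from compound 2 to compound 4 (0.16 log units; within the scatter), and the core exchange looks no different from the one made with piperidin-1-yl: the same change on two cores in this assay, a 1.1-fold higher number (0.05 log units; within the scatter) from compound 1 to compound 3 and a 1.5-fold higher number (0.16 log units; within the scatter) from compound 2 to compound 4, 1.3-fold (0.11 log units) apart, within the scatter of two such steps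

So within these four compounds the two changes act independently, and the effect of the amine swap carries over from one core to the other, but this rests on a single pair of cores and a single cell line, and it neither predicts the step on any further core nor explains why the number rises.

The compounds shown leave open whether the same carry-over holds for other amines at this place, such as morpholin-4-yl, pyrrolidin-1-yl, dimethylamino or piperazin-1-yl without its methyl group. They also leave open whether the gap between piperidin-1-yl and 4-methylpiperazin-1-yl would keep its size on a core that behaves less like these two.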